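Shared core series: dihydroxyphenyl in place of fluorophenyl

This account rests on a few compounds, and the source may have more. Where it says the series, first, only, none or still open, it means among the compounds named here.

Compound 1 `Fc1cccc(F)c1CSc1nnc(-c2ccncc2)n1-c1ccccc1` carries the shared core with no hydrazide arm. In a functional assay on HepG2 cells (Homo sapiens) for inhibition, read by MTT assay, with a stated time of 48 h (a higher number here means a weaker inhibitor, a lower number a stronger inhibitor), compound 1 gives > 50000 nM, which is a limit of the assay and not a number. Compound 2 `O=C(CSc1nnc(-c2ccncc2)n1-c1ccccc1)N/N=C/c1ccc(Cl)cc1` gives 11000 nM in this assay. Compound 3 `O=C(CSc1nnc(-c2ccncc2)n1-c1ccccc1)N/N=C/c1ccc(F)cc1` gives 9330 nM in this assay. Within the data shown here, the one measured step, a 1.2-fold lower number from compound 2 to compound 3 (0.07 log units; within the scatter), lies within the scatter. Compound 3 thus holds the lowest of the two numbers, with compound 2 nearest and within the scatter of it; the value of compound 1 is a limit and does not rank.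

Compound 4 `O=C(CSc1nnc(-c2ccncc2)n1-c1ccccc1)N/N=C/c1ccc(O)c(O)c1` differs from compound 3 only in the aryl ring attached to the carbon with a double bond to nitrogen: 3,4-dihydroxyphenyl in place of 4-fluorophenyl on a carbon with a double bond to nitrogen. Among the measured compounds shown here, the only step measured on that ring, a 1.2-fold lower number from compound 2 to compound 3 (0.07 log units; within the scatter), swapped one halogen for another and stayed within the scatter. For the measured compounds named here, no measured step exchanges a halogen for hydroxyl groups, so the direction is not fixed by the data. The expected step is a 1.2-fold lower number from compound 3 to compound 4 (0.07 log units; within the scatter). For compound 4 the expected value is 8000 nM. The low end for compound 4 is estimated at 2000 nM. The high end for compound 4 is estimated at 40000 nM.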

Compound 4, half-maximal inhibitory concentration: 16900 nM
The estimate for compound 4 lay 2.1-fold (0.32 log units) below the measured number; low and high end bracket the measured number.
By their numbers in this assay, from the lowest: compounds 3, 2 and 4 (each within the scatter of the next). At a limit, above all of these: compound 1.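

In this assay the aryl ring on the carbon with a double bond to nitrogen now has a step that brings in hydroxyl groups instead of trading one halogen for another: a 1.8-fold higher number from compound 3 to compound 4 (0.26 log units; within the scatter) and a 1.5-fold higher number from compound 2 to compound 4 (0.19 log units; within the scatter) both lie within the scatter. At this position, then, going from a ring with 0 hydrogen-bond donors and 0 hydrogen-bond acceptors to 3,4-dihydroxyphenyl with 2 of each leaves the number indistinguishable from those of the 4-fluorophenyl and 4-chlorophenyl compounds, a statement that holds for these three compounds only. Nothing in the data shown explains why this exchange stays within the scatter.

From the compounds shown here alone, whether an amine or a carboxylic acid on this aryl ring would move the number beyond the scatter stays open, as does whether a single hydroxyl group would read like the pair. Going by these compounds, for compound 1 the entry > 50000 nM is a limit of the assay and not a number, and that compound differs from the others in more than one place, so what the hydrazide arm contributes also stays open.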